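The compounds below may be only part of what the source reports. "The series", "measured", "known", "first", "only" and "open" are said of these compounds alone.

Working notes on the series. In a functional assay on U-87MG ATCC cells for antiproliferative activity against U-87 MG (Homo sapiens), read by MTT assay, with a stated time of 48 h, tested at 10 uM (a higher number here means a weaker effect of the compound at the concentration tested, a lower number a stronger effect), compound 3 `Cc1nc(-c2ccc(Cl)cc2)sc1C(=O)CSc1nc(-c2cccc(Cl)c2)c(C#N)c(=O)[nH]1` gives 95.2%, the second highest of the three numbers. Its nearest neighbour is compound 2 `Cc1nc(-c2ccc(Cl)cc2)sc1C(=O)CSc1nc(-c2ccc(Cl)c(Cl)c2)c(C#N)c(=O)[nH]1`, which in this assay gives 97.1%; the step of a number 1.9 percentage points lower from compound 2 to compound 3 (within the scatter) lies within the scatter. Furthest is compound 1 `COc1ccc(-c2nc(C)c(C(=O)CSc3nc(-c4ccc(OC)cc4)c(C#N)c(=O)[nH]3)s2)cc1`, which in this assay gives 80.3%, beyond the scatter from compound 3. Compound 4 `COc1ccc(-c2nc(SCC(=O)c3sc(-c4ccc(Cl)cc4)nc3C)[nH]c(=O)c2C#N)cc1` differs from compound 3 by 4-methoxyphenyl in place of 3-chlorophenyl on an aromatic carbon. Going by the values given here, no measured step matches this change; the only step on record, hydrogen in place of chloro on an aromatic carbon, is within the scatter and says little here. Compound 1, which also carries 4-methoxyphenyl, gives 80.3% and hints at a downward move. Compound 4 is expected to give 87% in this assay, with a range from 74% to 100%. The estimated step of a number 8.2 percentage points lower from compound 3 to compound 4 (within the scatter) is thus expected to be modest, near the edge of the scatter.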

Compound 4, a percentage reported as activity, at one concentration (the size of the read-out at that concentration, not a potency): 88.3%
The estimate for compound 4 lay 1.3 percentage points below the measured number, within the range that was stated.
By their numbers in this assay, from the lowest: compounds 1, 4, 3 and 2 (each within the scatter of the next, the first and the last beyond it).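

In this assay, going by these compounds alone, the first direct reading at this position, next to the ring nitrogen, is the exchange of 3-chlorophenyl for 4-methoxyphenyl, with a number 6.9 percentage points lower from compound 3 to compound 4 (within the scatter). The exchange of 3,4-dichlorophenyl for 4-methoxyphenyl at the same place gives a number 8.8 percentage points lower from compound 2 to compound 4 (within the scatter), and chloro in place of methoxy on an aromatic carbon gives a number 8 percentage points higher from compound 1 to compound 4 (within the scatter), so no single change here separates from the scatter. Nothing available explains these steps. The compounds shown leave open whether an aminophenyl group, a carboxyphenyl group or a longer alkyl chain at this position would move the number beyond the scatter.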